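The source may hold more compounds than are shown below. What is called first, only, known or untested is meant among the compounds shown, and "the series" means these compounds.

Measured compounds:
- compound 1 `Cc1ccc(CCC(=O)N[C@@H](C(=O)N2CCC(c3ccc(Cl)cc3)CC2)C(C)C)cc1`: 105 nM in an assay on THP-1 cells for displacement of a labelled ligand from C-C chemokine receptor type 1 (Homo sapiens); on this read-out higher numbers stand for weaker inhibition and lower numbers for stronger inhibition
- compound 2 `CC[C@@H](NC(=O)c1ccccc1)C(=O)N1CCC(c2ccc(Cl)cc2)CC1`: 121 nM
- compound 3 `CCCC(NC(=O)c1ccccc1C)C(=O)N1CCC(c2ccc(Cl)cc2)CC1`: 152 nM

All three share the same core, a piperidine amide carrying a para-chlorophenyl group, and differ in the acyl group and in the side chain of the amino acid that links the two amides. On the numbers shown, compound 1 has the lowest value, but the gap to compound 2 and the gap to compound 3 are both within the scatter of this assay, so nothing can be said about an order among them.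

Compound 4 `Cc1cccc(CCC(=O)N[C@@H](C(=O)N2CCC(c3ccc(Cl)cc3)CC2)C(C)C)c1` has not yet been measured. It differs from compound 1 by 3-methylphenyl in place of 4-methylphenyl on a saturated chain carbon, two bonds along the chain from a carbonyl carbon. Within the data shown here, nothing among the measured compounds speaks to a shift of this kind, since the three pairs of measured compounds each differ in more than one place, so there is no step of the same kind to lean on. The default expectation is therefore no step beyond the scatter in this assay, in either direction.

Compound 4 is accordingly expected to give about 130 nM, with a likely range from 55 nM to 320 nM. The step this estimate means, a 1.2-fold higher number from compound 1 to compound 4 (0.09 log units; within the scatter), is expected to stay within the usual scatter.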

Compound 4, half-maximal inhibitory concentration: 22 nM
For compound 4 the middle estimate is 5.9-fold (0.77 log units) above the measured one; the measured number lies below the stated range.
By their numbers in this assay, from the lowest: compound 4; then compounds 1, 2 and 3 (each within the scatter of the next).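

In this assay, among these compounds, 3-methylphenyl in place of 4-methylphenyl on a saturated chain carbon, two bonds along the chain from a carbonyl carbon, gives a 4.8-fold lower number from compound 1 to compound 4 (0.68 log units; beyond the scatter), the only step read so far between compounds that differ in one place. Among the compounds shown here, the two compounds have the same atoms and the leaving and entering groups match in every count, so this position of the series responds to where the methyl sits on the phenyl ring, even with the composition unchanged, which the earlier compounds, all within the scatter of one another, could not show. No measurement at hand accounts for the step.

Open, from the compounds shown here alone, is whether the methyl itself contributes: an unsubstituted phenyl, or a chlorine or a methoxy group in place of the methyl on the 3-methylphenyl, would settle that. Also open, going by these compounds, is how far the step carries: it rests on one pair with one side chain, and a longer chain between the carbonyl and the ring, or the side chains of compound 2 and compound 3, could give a different answer.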